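Butyl to Cyclohexyl: Expected Cytotoxicity of Compound 4

This account rests on a few compounds, and the source may have more. Where it says the series, first, only, none or still open, it means among the compounds named here.

Cytotoxicity here is measured in an ADME assay on THP-1 cells (Homo sapiens) for cytotoxicity, read by resazurin assay, with a stated time of 72 h; on this read-out higher numbers stand for lower toxicity in this test and lower numbers for higher toxicity in this test. Among the compounds with values here, compound 1 `CCCCc1ccc(C(=O)/C=C/c2ccc([N+](=O)[O-])s2)cc1` gives 17100 nM in this assay, the only actual number among the three measured compounds. Compound 2 `CN(C)c1ccc(/C=C/C(=O)c2ccc(-c3ccccc3)cc2)cc1` reaches only the assay limit of > 50000 nM. Compound 3 `O=C(/C=C/c1cccc([N+](=O)[O-])c1)c1ccc(N2CCCCC2)cc1` likewise sits at the limit of > 50000 nM. This matters because of the limit of > 50000 nM in this assay, at which 2 of the 3 values shown sit, so little can be said about how the measured structures differ in effect.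

Compound 4 `O=C(/C=C/c1ccc([N+](=O)[O-])s1)c1ccc(C2CCCCC2)cc1` differs from compound 1 by cyclohexyl in place of butyl on an aromatic carbon. Within the data shown here, no comparable measured pair exists, so the step from compound 1 to compound 4 is expected to stay within the usual scatter, a 1.3-fold higher number from compound 1 to compound 4 (0.11 log units; within the scatter). Compound 4 is therefore estimated at 22000 nM, with a range from 9000 nM to 55000 nM.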

Compound 4, half-maximal cytotoxic concentration: > 50000 nM
Compound 4: a limit, no number; the forecaster's own chance of this, stated with the estimate: 30%; middle value at least 2.2-fold (0.35 log units) from the limit.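

In this assay, within the data shown here, putting cyclohexyl in place of butyl on this aromatic carbon gives an at least 2.9-fold higher number from compound 1 to compound 4 (0.46 log units; beyond the scatter) and is the first step between measured compounds that can be read. It shows that this position responds to the change, with the ring going along with lower toxicity in this test. As far as these compounds go, the full size of the step stays unknown, because compound 4 gives a limit and not a number: (the limit of > 50000 nM in this assay, at which 3 of the 4 values shown sit).

The compounds shown leave open whether the ring itself or simply the larger carbon group matters. A straight hexyl chain or an amine at this place would help to separate these.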